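Aryl-substituted triazine core: iodo in place of ethyl

The source may hold more compounds than are shown below. What is called first, only, known or untested is meant among the compounds shown, and "the series" means these compounds.

Working notes on a small set sharing one core, measured in an assay for inhibition of Dihydrofolate reductase (Bos taurus), at pH 7.20; on this read-out higher numbers stand for higher potency (the scale is a negative logarithm) and lower numbers for lower potency. Compound 1 `CC1(C)N=C(N)N=C(N)N1c1ccccc1N` carries an amino group on the aromatic ring and in this assay compound 1 gives 4.58. Compound 2 `CSc1ccccc1N1C(N)=NC(N)=NC1(C)C` carries methylsulfanyl there, and in this assay compound 2 gives 3.91. Compound 3 `CCc1ccccc1N1C(N)=NC(N)=NC1(C)C` carries ethyl, and in this assay compound 3 gives 4.48.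

Compound 3 stands second highest of the three numbers; compound 1 is nearest to it and compound 2 furthest. The steps that change this ring substituent are a number 0.10 log units lower from compound 1 to compound 3 (within the scatter), a number 0.67 log units lower from compound 1 to compound 2 (beyond the scatter) and a number 0.57 log units higher from compound 2 to compound 3 (beyond the scatter): the swap of amino for ethyl left the number where it was, while methylsulfanyl lowered it.

Compound 4 `CC1(C)N=C(N)N=C(N)N1c1ccccc1I` is not yet measured. Its change from compound 3 is iodo in place of ethyl on an aromatic carbon, placed on an aromatic carbon of a six-membered aromatic ring of carbon only, ortho to a large group. Within the data shown here, no measured step involves iodo, so the closest guide is a number 0.10 log units lower from compound 1 to compound 3 (within the scatter), a step within the scatter. On that basis the step of a number 0.08 log units lower from compound 3 to compound 4 (within the scatter) is expected to stay within the scatter, and compound 4 is estimated to give 4.4 in this assay, with a range from 3.9 to 4.9.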

Compound 4, logarithm of the reciprocal of the active concentration, log(1/C): 3.75
Compound 4: middle estimate off by 0.65 log units, on the high side; the whole stated range lies above it.
By their numbers in this assay, from the lowest: compounds 4 and 2 (each within the scatter of the next); then compounds 3 and 1 (each within the scatter of the next).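

In this assay this aromatic carbon proves sensitive to the swap to iodo: the step is a number 0.73 log units lower from compound 3 to compound 4 (beyond the scatter), and against amino it is a number 0.83 log units lower from compound 1 to compound 4 (beyond the scatter), whereas against methylsulfanyl it is only a number 0.16 log units lower from compound 2 to compound 4 (within the scatter), so the four groups now fall into two pairs, iodo with methylsulfanyl and ethyl with amino. Ethyl and iodo have the same counts of hydrogen-bond donors and acceptors and neither carries a net charge, so these counts do not separate the two groups. Nothing at hand bears on what lies behind the drop seen with iodo.

From the compounds shown here alone, whether fluoro, chloro or bromo would stay with iodo or join ethyl remains open, as does where hydroxy, methoxy or a longer chain such as propyl would fall. Going by these compounds, all four compounds vary this one position on the shared core, so it also remains open whether the two pairs would hold with these groups placed elsewhere on the aromatic ring.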